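A few compounds are considered here, and "the series" means these few. Any claim that something is new, unique, unknown or untested is made for them only; others in the source may bear on it.

Compound 1 `CC(C)(C)Sc1c(CC(C)(C)C(=O)O)n(Cc2ccc(Cl)cc2)c2ccc(OCc3ccc4cc(F)c(F)cc4n3)cc12`: > 3000 nM, a limit of the assay
Compound 2 `CC(C)(C)Sc1c(CC(C)(C)C(=O)O)n(Cc2ccc(Cl)cc2)c2ccc(OCc3nc4ccccc4s3)cc12`: 260 nM
Compound 3 `CC(C)(C)Sc1c(CC(C)(C)C(=O)O)n(Cc2ccc(Cl)cc2)c2ccc(OCc3cccc(Cl)n3)cc12`: 410 nM

For the measured compounds named here, in a functional assay (blood) for inhibition, with Homo sapiens as the target (a lower number here means a stronger inhibitor, a higher number a weaker inhibitor), compound 3 stands level with the only other exact number: a 1.6-fold higher number from compound 2 to compound 3 (0.20 log units; within the scatter). Going by the values given here, that exchange of one group for another is the closest precedent for compound 4 `CC(C)(C)Sc1c(CC(C)(C)C(=O)O)n(Cc2ccc(Cl)cc2)c2ccc(OCc3cccs3)cc12`, which has thiophen-2-yl in place of 6-chloropyridin-2-yl on a saturated chain carbon bound to an oxygen on an aromatic ring. The other two steps, an at least 11-fold lower number from compound 1 to compound 2 (1.06 log units; beyond the scatter) and an at least 7.3-fold lower number from compound 1 to compound 3 (0.86 log units; beyond the scatter), show that a change at this place can be large, so a weaker result remains possible. Even so, no shift beyond the scatter is expected, and the estimated change is a 1.1-fold lower number from compound 3 to compound 4 (0.03 log units; within the scatter). The expected value for compound 4 is 380 nM, with an estimated range of 140 nM to 1100 nM.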

Compound 4, half-maximal inhibitory concentration: > 3000 nM
Compound 4: only a limit was reported (the forecaster's own chance of this, stated with the estimate: 7%); middle value at least 7.8-fold (0.89 log units) from the limit.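

In this assay thiophen-2-yl does far worse at this place than two other groups: the exchange for 6-chloropyridin-2-yl gives an at least 7.3-fold higher number from compound 3 to compound 4 (0.86 log units; beyond the scatter) and the exchange for 1,3-benzothiazol-2-yl gives an at least 11-fold higher number from compound 2 to compound 4 (1.06 log units; beyond the scatter). The poor end is thus reached by the smallest group shown as well as by the largest, so heavy-atom count alone does not order these compounds. The step from compound 1 to compound 4 cannot be read, both values being limits: the limit of > 3000 nM in this assay, at which 2 of the 4 values shown sit. As far as these compounds go, whether a chlorine on the thiophen-2-yl ring would restore activity remains open, as does the result with an amine or a carboxylic acid on this ring.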